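The compounds below may be only part of what the source reports. "The series", "measured", "known", "first", "only" and "open" are said of these compounds alone.

Measured so far:
compound 1 `NS(=O)(=O)c1ccc(Nc2nc(N/N=C/c3ccc(C(F)(F)F)cc3)nc(Nc3ccccc3)n2)cc1` with 1820 nM in a functional assay on RXF 393 cells (Homo sapiens) for inhibition, read by sulforhodamine B assay, with a stated time of 48 h; a higher number here means a weaker inhibitor of growth, a lower number a stronger inhibitor of growth
compound 2 `Cc1nn(-c2ccccc2)cc1/C=N/Nc1nc(Nc2ccccc2)nc(Nc2ccc(S(N)(=O)=O)cc2)n1` with 1770 nM in this assay

Compound 2 and compound 1 give numbers within the scatter of each other, so neither can be set above the other. Compound 3 `NS(=O)(=O)c1ccc(Nc2nc(N/N=C/c3ccccn3)nc(Nc3ccccc3)n2)cc1` carries pyridin-2-yl in place of 3-methyl-1-phenyl-1H-pyrazol-4-yl on a carbon with a double bond to nitrogen. For the measured compounds named here, the one measured step at this same carbon, a 1.0-fold lower number from compound 1 to compound 2 (0.01 log units; within the scatter), swapped one aromatic group for another and moved nothing beyond the scatter. For compound 3 a step of similar size is therefore expected, a 1.0-fold higher number from compound 2 to compound 3 (0.01 log units; within the scatter), with no clear direction. The estimate for compound 3 in this assay is 1800 nM, within 600 nM to 5400 nM.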

Compound 3, concentration for 50% growth inhibition: 1070 nM
For compound 3 the middle estimate is 1.7-fold (0.23 log units) above the measured one; measured number inside the range.
By their numbers in this assay, from the lowest: compounds 3, 2 and 1 (each within the scatter of the next).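

Going from two rings to one at this carbon, with 3-methyl-1-phenyl-1H-pyrazol-4-yl replaced by the smaller pyridin-2-yl, gives a 1.7-fold lower number from compound 2 to compound 3 (0.22 log units; within the scatter) in this assay. The swap of 4-(trifluoromethyl)phenyl for pyridin-2-yl gives a 1.7-fold lower number from compound 1 to compound 3 (0.23 log units; within the scatter), so among these three compounds neither ring count nor group size separates the numbers. No supporting measurement is available to interpret these results. As far as these compounds go, all three groups here are aromatic rings, so the effect of an amine, a carboxylic acid or a longer alkyl chain on this carbon remains open.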